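Indole side chain: amide in place of diamine

This account rests on a few compounds, and the source may have more. Where it says the series, first, only, none or still open, it means among the compounds named here.

Among the compounds with values here, compound 1 `NCC(N)CCc1c[nH]c2ccc(F)cc12` is the only member of the series with a numerical result so far. In an assay on isolated protein for inhibition of Myeloperoxidase (Homo sapiens), read by ELISA, with a stated time of 5 min (a higher number here means a weaker inhibitor, a lower number a stronger inhibitor), compound 1 gives 26 nM. Within the data shown here, the only other measured entry is compound 2 `NCCCc1c[nH]c2ccc(C(=O)O)cc12`, which carries a carboxylic acid on the core and a shorter amine chain; in this assay compound 2 is recorded as "not active" (no number reported), so no number stands beside it and no step between the two measured compounds can be computed.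

Compound 3 `CCNC(=O)CCCc1c[nH]c2ccc(F)cc12` has not yet been measured in this assay. It differs from compound 1 by (ethylcarbamoyl)methyl in place of 1,2-diaminoethyl on a saturated chain carbon, two bonds along the chain from an aromatic carbon. Both amines of the side chain thus leave and an amide enters in their place, with the attachment point on the chain unchanged.

Among the measured compounds shown here, no measured pair shows what such a change does here. For the measured compounds named here, since compound 1 is the sole compound with a number, 26 nM, and compound 2 without a basic chain gives "not active" (no number reported), the expectation for compound 3 is a weaker result, with a step of a 77-fold higher number from compound 1 to compound 3 (1.89 log units; beyond the scatter). The estimate for compound 3 in this assay is 2000 nM, expected to fall between 300 nM and 20000 nM.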

Compound 3, half-maximal inhibitory concentration: 243 nM
Compound 3: the middle estimate sits 8.2-fold (0.92 log units) above what was measured; measured number below the stated range.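

In this assay, (ethylcarbamoyl)methyl in place of 1,2-diaminoethyl on a saturated chain carbon, two bonds along the chain from an aromatic carbon, gives a 9.3-fold higher number from compound 1 to compound 3 (0.97 log units; beyond the scatter). Within the data shown here, this is the first numerical reading of a change at this position: both amines of the side chain can go and compound 3 still gives 243 nM, so a numerical result in this assay does not depend on keeping the 1,2-diaminoethyl group, although compound 1 remains the stronger of the two. No measurement accompanying these compounds bears on why the number rises.

This single step removes both amines and introduces the amide together, so the share of each part in the change remains unresolved; a side chain carrying one amine on the core of compound 1 would begin to separate them. Also open, on these data alone, is how much the ethyl group on the amide contributes, which a primary amide, a methyl amide or a longer chain on the amide nitrogen could test at the same position.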